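The source may hold more compounds than are shown below. What is called first, only, known or untested is meant among the compounds shown, and "the series" means these compounds.

Of the compounds shown here, three have been measured in a physicochemical assay for solubility, in phosphate buffer, measured as kinetic solubility, with a stated time of 1 h, at pH 7.4; on this read-out lower numbers stand for lower solubility and higher numbers for higher solubility. Compound 1 `CCNC(=O)Nc1ccc(-c2nc(CS(C)(=O)=O)cc([C@]34CCOC[C@H]3C4)n2)cc1` gives 96 ug/mL in this assay. Compound 2 `CCNC(=O)Nc1ccc(-c2nccc([C@]34CCOC[C@H]3C4)n2)cc1` gives 125 ug/mL in this assay. The difference between these two structures is (methylsulfonyl)methyl in place of hydrogen on an aromatic carbon, and the step that it made was a 1.3-fold lower number from compound 2 to compound 1 (0.11 log units; within the scatter). Compound 3 `Oc1cccc(-c2nccc([C@]34CCOC[C@H]3C4)n2)c1` gives 141 ug/mL in this assay; how its core differs from the core of compound 2 is not broken down here, and the numbers of compound 3 and compound 2 lie within the scatter of each other, as do those of compound 3 and compound 1.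

Compound 4 `CS(=O)(=O)Cc1cc([C@]23CCOC[C@H]2C3)nc(-c2cccc(O)c2)n1` has not yet been measured. It differs from compound 3 by (methylsulfonyl)methyl in place of hydrogen on an aromatic carbon. For the measured compounds named here, this is the same kind of change as the one from compound 2 to compound 1, though the surroundings are not described in the same words: from compound 3 to compound 4 the place is meta to a 3-hydroxyphenyl group, whereas from compound 2 to compound 1 it is meta to a large group.

The step from compound 3 to compound 4 in this assay is expected to be small, estimated as a 1.3-fold lower number from compound 3 to compound 4 (0.11 log units; within the scatter). This expectation rests on compound 2 and compound 1, because a 1.3-fold lower number from compound 2 to compound 1 (0.11 log units; within the scatter) lay within the scatter. Compound 4 is therefore estimated to give 110 ug/mL in this assay, expected to fall between 60 ug/mL and 200 ug/mL.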

Compound 4, solubility: 75 ug/mL
For compound 4 the middle estimate is 1.5-fold (0.17 log units) above the measured one, and the stated range covers the measured number.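

Placed on an aromatic carbon of the core of compound 3, (methylsulfonyl)methyl in place of hydrogen gave in this assay a 1.9-fold lower number from compound 3 to compound 4 (0.27 log units; within the scatter) and, on the core of compound 2, the same kind of change gave a 1.3-fold lower number from compound 2 to compound 1 (0.11 log units; within the scatter) as its step. For the compounds shown here, both steps run in the same direction and both lie within the scatter, so on these two cores the change has not moved the read-out by more than repeated measurements would, and the small step seen on one core is matched on the other; with only two pairs, however, this shows neither that the group truly lowers the number nor that a step of this size would hold on any further core. Nothing measured here bears on why the two steps look as they do.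

The compounds shown leave open how other groups at this same place, such as an amine or a carboxylic acid, would compare with (methylsulfonyl)methyl on either core. They also leave open whether a longer chain ending in the same sulfonyl group would keep the step within the scatter.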